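Compound 3 to compound 4: a tetrazole on the chain

This account rests on a few compounds, and the source may have more. Where it says the series, first, only, none or still open, it means among the compounds named here.

Measured so far in a physicochemical assay for solubility, in phosphate buffer, measured as thermodynamic solubility, at pH 7.4; a higher number here means a more soluble compound, a lower number a less soluble compound:
- compound 1 `CNC(=O)CCc1cn(-c2ccc(Br)cc2)nc1-c1ccc(Cl)cc1` gives < 5000 nM (a limit, not a number)
- compound 2 `CC(=O)NS(=O)(=O)CCc1cn(-c2ccc(Br)cc2)nc1-c1ccc(Cl)cc1` gives 165000 nM
- compound 3 `O=C(CCc1cn(-c2ccc(Br)cc2)nc1-c1ccc(Cl)cc1)NS(=O)(=O)C1CC1` gives 5000 nM

Of the two exact numbers in this assay, compound 3 at 5000 nM holds the lower one and compound 2 at 165000 nM the higher. Compound 1 carries only a limit. The comparison a number no lower from compound 1 to compound 3 (the limit leaves the size open) therefore has no readable size.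

Next comes compound 4 `Clc1ccc(-c2nn(-c3ccc(Br)cc3)cc2CCc2nnn[nH]2)cc1`, with 1H-tetrazol-5-yl in place of (cyclopropylsulfonyl)carbamoyl on a saturated chain carbon, two bonds along the chain from an aromatic carbon and the rest of the structure unchanged.

Two measured steps change this same place, both large and beyond the scatter: an at least 33-fold higher number from compound 1 to compound 2 (1.51 log units; beyond the scatter) and a 33-fold lower number from compound 2 to compound 3 (1.52 log units; beyond the scatter) in the opposite sense. Neither brings in a tetrazole, so they show how far the read-out can move here and fix no direction for this change. With compound 3 at the low end of the exact numbers, a move upward of moderate size is expected, smaller than the swing seen with compound 2 at 165000 nM in the same series. The expected change is a 5.0-fold higher number from compound 3 to compound 4 (0.70 log units; beyond the scatter) and is only an estimate. For compound 4 the estimated value is 25000 nM with an expected range from 5000 nM to 150000 nM in this read-out. A reading at the limit of < 5000 nM in this assay, at which 1 of the 3 values shown sits, also remains possible.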

Compound 4, solubility: 150000 nM
Estimate against measurement, compound 4: 6.0-fold (0.78 log units) below, and the stated range covers the measured number.
By their numbers in this assay, from the lowest: compound 3; then compounds 4 and 2 (each within the scatter of the next).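

In this assay, 1H-tetrazol-5-yl in place of (cyclopropylsulfonyl)carbamoyl on the saturated chain carbon gives a 30-fold higher number from compound 3 to compound 4 (1.48 log units; beyond the scatter), and the two groups carry the same counts of hydrogen-bond donors and acceptors, so those counts do not track the read-out at this place in this pair. The aromatic ring of compound 4 and the open acetylsulfamoyl group of compound 2 cannot be told apart here, with a 1.1-fold lower number from compound 2 to compound 4 (0.04 log units; within the scatter), so two different groups at this place now share the high end of the exact numbers, while (cyclopropylsulfonyl)carbamoyl in compound 3 goes against any reading that groups of this kind give high numbers as a class. The same tetrazole also gives an at least 30-fold higher number from compound 1 to compound 4 (1.47 log units; beyond the scatter), a size that rests on a limit and not on a number: the limit of < 5000 nM in this assay, at which 1 of the 4 values shown sits.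

Open, going by these compounds, is how a carboxylic acid or an amine on this chain would read, and whether a longer chain carrying the 1H-tetrazol-5-yl would hold the number. Also open is whether the cyclopropyl ring or the order of carbonyl and sulfonyl sets compound 3 apart from compound 2, as the compounds shown do not separate the two.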